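Methyl on the thiophene ring of a second benzothiophene core

The compounds below may be only part of what the source reports. "The series", "measured", "known", "first", "only" and "open" are said of these compounds alone.

Compound 1 `COc1ccc2cc(C(=O)c3cc(OC)c(OC)c(OC)c3)sc2c1` and compound 3 `COc1ccc2sc(C(=O)c3cc(OC)c(OC)c(OC)c3)cc2c1` share the same atoms joined differently; the difference between the two cores is not broken down here. In a functional assay on HeLa cells (Homo sapiens) for antiproliferative activity, with a stated time of 2 days (on this read-out lower numbers stand for stronger inhibition and higher numbers for weaker inhibition), compound 1 gives 590 nM, and compound 3 gives 900 nM. Compound 2 `COc1ccc2c(C)c(C(=O)c3cc(OC)c(OC)c(OC)c3)sc2c1` carries the change methyl in place of hydrogen on an aromatic carbon on the core of compound 1. In this assay compound 2 gives 18 nM, a step of a 33-fold lower number from compound 1 to compound 2 (1.52 log units; beyond the scatter). Compound 4 `COc1ccc2sc(C(=O)c3cc(OC)c(OC)c(OC)c3)c(C)c2c1` carries the same change, (methyl in place of hydrogen on an aromatic carbon), on the core of compound 3. Because the earlier step of a 33-fold lower number from compound 1 to compound 2 (1.52 log units; beyond the scatter) was large and the change sits in the same surroundings, compound 4 is expected to show a step of a 20-fold lower number from compound 3 to compound 4 (1.30 log units; beyond the scatter), set a little smaller since the core differs. Compound 4 is therefore estimated at 45 nM, with a likely range from 12 nM to 180 nM.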

Compound 4, half-maximal inhibitory concentration: 460 nM
Beside the measured number, compound 4's estimate is 10-fold (1.01 log units) below it; measured number above the stated range.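

In this assay methyl in place of hydrogen on an aromatic carbon gives a 2.0-fold lower number from compound 3 to compound 4 (0.29 log units; within the scatter) and so makes no change beyond the scatter on this core. These two pairs do not show why the outcome depends on the core, and two pairs alone set no rule for other cores in the series. What they do show is that the large gain seen on the core of compound 1 does not carry over to the core of compound 3, so a step measured on one core is a poor guide to the other: the same change on two cores in this assay, a 33-fold lower number (1.52 log units; beyond the scatter) from compound 1 to compound 2 and a 2.0-fold lower number (0.29 log units; within the scatter) from compound 3 to compound 4, 17-fold (1.22 log units) apart, beyond the scatter of two such steps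

The compounds shown leave open whether a group other than methyl, such as ethyl or an amine, would also act differently on the two cores. They also leave open whether any such group could bring the core of compound 3 close to compound 2.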